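From carbamoyl to phenyl on the amine chain

The source may report more compounds than this note shows. Statements on the series, on what has been measured and on what is new or still open speak of the compounds shown alone.

- compound 1 `CC(C)=CCc1cc(C(=O)Nc2cc3ccc(OCCCN(C)C(C)C)c(C)c3oc2=O)ccc1O` gives 1050 nM
- compound 2 `CC(C)=CCc1cc(C(=O)Nc2cc3ccc(OCCCNCC(N)=O)c(C)c3oc2=O)ccc1O` gives 1460 nM

In a functional assay on MCF7 cells (Homo sapiens) for antiproliferative activity (a lower number here means a stronger inhibitor, a higher number a weaker inhibitor), compound 2 gives 1460 nM and stands level with compound 1 within the usual scatter. Compound 3 `CC(C)=CCc1cc(C(=O)Nc2cc3ccc(OCCCNCc4ccccc4)c(C)c3oc2=O)ccc1O` carries one change from compound 2 phenyl in place of carbamoyl on a saturated chain carbon bound to an amine nitrogen and so has phenyl in place of carbamoyl on a saturated chain carbon bound to an amine nitrogen. Among the measured compounds shown here, the only measured step that bears on this is a 1.4-fold higher number from compound 1 to compound 2 (0.14 log units; within the scatter) and it stayed within the scatter. One step is thin evidence, but no change beyond the scatter is expected in this assay here. The expected step is a 1.2-fold lower number from compound 2 to compound 3 (0.07 log units; within the scatter) and no more. For compound 3 the estimated value is 1250 nM with an expected range from 450 nM to 3500 nM.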

Compound 3, half-maximal inhibitory concentration: 910 nM
The estimate for compound 3 lay 1.4-fold (0.14 log units) above the measured number, and the stated range covers the measured number.
By their numbers in this assay, from the lowest: compounds 3, 1 and 2 (each within the scatter of the next).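

In this assay, phenyl in place of carbamoyl on a saturated chain carbon bound to an amine nitrogen brings an aromatic ring where there was none, yet gives a 1.6-fold lower number from compound 2 to compound 3 (0.21 log units; within the scatter). Benzylamino in place of isopropyl(methyl)amino gives a 1.2-fold lower number from compound 1 to compound 3 (0.06 log units; within the scatter), so three quite different amine ends have now produced no step beyond the scatter. No measured evidence bears on this result.

Still open, from the compounds shown here alone, is whether a carboxylic acid on this chain, or a longer chain between the oxygen and the amine, would move the number beyond the scatter.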